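Aryl halogen exchange on two cores

The compounds below may be only part of what the source reports. "The series", "measured", "known", "first", "only" and "open" are said of these compounds alone.

Values in a functional assay on PANC-1 cells (Homo sapiens) for antiproliferative activity (on this read-out lower numbers stand for stronger inhibition and higher numbers for weaker inhibition), for the measured compounds:
compound 1 `CC[C@H](C)[C@H]1C(=O)N[C@H](Cc2cc(Cl)c(O)c(Cl)c2)C(=O)N[C@@H](C(C)(C)O)C(=O)O[C@H](c2ccccc2)[C@H](C)/C=C/C=C(\C)[C@H](OC)C[C@@H]2O[C@@]2(C)C(=O)N1C` gives 12.2 nM
compound 2 `CC[C@H](C)[C@H]1C(=O)N[C@H](Cc2ccc(O)c(Br)c2)C(=O)N[C@@H](C(C)(C)O)C(=O)O[C@H](c2ccccc2)[C@H](C)/C=C/C=C(\C)[C@H](OC)C[C@@H]2O[C@@]2(C)C(=O)N1C` gives 9.61 nM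
compound 3 `CC[C@H](C)[C@H]1C(=O)N[C@H](Cc2cc(Cl)c(O)c(Cl)c2)C(=O)N[C@@H](C(C)C)C(=O)O[C@H](c2ccccc2)[C@H](C)/C=C/C=C(\C)[C@H](OC)C/C=C(\C)C(=O)N1C` gives 137 nM

Compound 1 and compound 2 share one core and differ only in 3-bromo-4-hydroxyphenyl in place of 3,5-dichloro-4-hydroxyphenyl on a saturated chain carbon bound to a saturated ring carbon. The step is a 1.3-fold lower number from compound 1 to compound 2 (0.10 log units; within the scatter), so the two numbers cannot be told apart by this measurement.

Compound 3 sits on a second core; the difference between the two cores is not broken down here. In this assay compound 3 gives 137 nM, which stands beyond the scatter above both compound 1 and compound 2.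

Compound 4 `CC[C@H](C)[C@H]1C(=O)N[C@H](Cc2ccc(O)c(Br)c2)C(=O)N[C@@H](C(C)C)C(=O)O[C@H](c2ccccc2)[C@H](C)/C=C/C=C(\C)[C@H](OC)C/C=C(\C)C(=O)N1C` is built on the core of compound 3 and differs from it by 3-bromo-4-hydroxyphenyl in place of 3,5-dichloro-4-hydroxyphenyl on a saturated chain carbon bound to a saturated ring carbon. This is the same change as that from compound 1 to compound 2, made at the same place. Because the earlier step of a 1.3-fold lower number from compound 1 to compound 2 (0.10 log units; within the scatter) stayed within the scatter, the expectation is that the step from compound 3 to compound 4 will also be small, estimated at a 1.2-fold lower number from compound 3 to compound 4 (0.10 log units; within the scatter). The expectation rests on a single prior pair only, and the change of core is not broken down, so the range is kept wide. For compound 4 in this assay the estimate is 110 nM, expected to fall between 50 nM and 250 nM.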

Compound 4, half-maximal inhibitory concentration: 55.8 nM
Compound 4: the middle estimate sits 2.0-fold (0.29 log units) above what was measured; measured number inside the range.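

On the second core, the exchange of 3,5-dichloro-4-hydroxyphenyl for 3-bromo-4-hydroxyphenyl gives a 2.5-fold lower number from compound 3 to compound 4 (0.39 log units; beyond the scatter) in this assay, a modest step. Set beside the same change on the first core, this step cannot be told apart from the earlier one: the same change on two cores in this assay, a 1.3-fold lower number (0.10 log units; within the scatter) from compound 1 to compound 2 and a 2.5-fold lower number (0.39 log units; beyond the scatter) from compound 3 to compound 4, 1.9-fold (0.29 log units) apart, within the scatter of two such steps. Going by these compounds alone, the change therefore carries across these two cores with no detectable difference in the size of the step, although only the step on the second core clears the scatter on its own, and two pairs neither fix a general size for the step nor predict it on any further core.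

The exchange replaces chlorine with bromine and also reduces the number of halogen atoms on the ring, so the compounds shown do not separate these two parts of the change, and the differences between the two cores also remain unresolved. On these data alone, it remains open how the series would respond to other groups on this aromatic ring, such as an iodine atom or a nitrile, or to a methoxy group in place of the hydroxyl.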